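Swapping an amino group for a pyridine ring on a shared core

This account rests on a few compounds, and the source may have more. Where it says the series, first, only, none or still open, it means among the compounds named here.

Compound 1 `COc1ccc(-c2cc(-c3cc(OC)c(OC)c(OC)c3)nc(N)n2)cc1` was tested in an ADME assay on THP-1 cells (Homo sapiens) for cytotoxicity, read by MTT assay (a lower number here means that less compound is tolerated, a higher number that more compound is tolerated), and compound 1 gives 100000 nM. Going by the values given here, compound 2 `COc1cc(C2CC(c3ccc(Br)cc3)=NN2C(C)=O)cc(OC)c1OC` is the only other compound with a result, and in this assay compound 2 gives 100000 nM. The two values are level at the digits shown, so compound 1 stands alongside compound 2 within the usual scatter, and there is no step between them to draw on. Compound 3 `COc1ccc(-c2cc(-c3cc(OC)c(OC)c(OC)c3)nc(-c3ccccn3)n2)cc1` has not yet been measured; it differs from compound 1 by pyridin-2-yl in place of amino on an aromatic carbon. Among the compounds with values here, with no measured step of this kind, the expectation rests on compound 1 alone. The change from compound 1 to compound 3 is expected to be a 1.4-fold lower number from compound 1 to compound 3 (0.15 log units; within the scatter), small and leaning toward less compound being tolerated. Compound 3 is therefore estimated at 70000 nM, with a range from 20000 nM to 100000 nM.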

Compound 3, half-maximal cytotoxic concentration: 50000 nM
Compound 3: middle estimate off by 1.4-fold (0.15 log units), on the high side, within the range that was stated.
By their numbers in this assay, from the lowest: compounds 3, 1 and 2 (each within the scatter of the next).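

In this assay, placing pyridin-2-yl in place of amino on this aromatic carbon gives a 2.0-fold lower number from compound 1 to compound 3 (0.30 log units; within the scatter), so the change stays inside the normal spread of repeat measurements. This first reading at the position between two ring nitrogen atoms shows that a larger group with its own ring, carrying no hydrogen-bond donor, can stand there without a clear shift in this cell test. Nothing available explains this outcome or ties it to any feature of either group.

Going by these compounds, whether a phenyl ring, a methyl group or a dimethylamino group would read the same at this position remains open. A single step also cannot show whether the same swap would stay within the scatter on a different core.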